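The compounds below may be only part of what the source reports. "The series", "measured", "known", "first", "only" and "open" are said of these compounds alone.

Measured in a functional assay on HT-29 cells (Homo sapiens) for cytotoxicity, read by sulforhodamine B assay; a higher number here means a weaker inhibitor of growth, a lower number a stronger inhibitor of growth:
- compound 1 `COC1=C(Br)[C@H](O)[C@@]2(C=C1Br)CC(C(=O)NCCCCCNC(=O)C1=NO[C@]3(C=C(Br)C(=O)[C@@H](Br)[C@@H]3O)C1)=NO2`: 2800 nM
- compound 2 `O=C(NCCCCCNC(=O)C1=NO[C@]2(C=C(Br)C(=O)[C@@H](Br)[C@@H]2O)C1)C1=NO[C@]2(C=C(Br)C(=O)[C@@H](Br)[C@@H]2O)C1`: 1500 nM
- compound 3 `COC1=C(Br)[C@H](O)[C@@]2(C=C1Br)CC(C(=O)NCCCCNC(=O)C1=NO[C@]3(C=C(Br)C(=O)[C@@H](Br)[C@@H]3O)C1)=NO2`: 4100 nM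

Compound 1, at 2800 nM, lies within the scatter of both compound 2 and compound 3, so its place among the three carries little weight. The next compound to consider is compound 4 `COC1=C(Br)[C@H](O)[C@@]2(C=C1Br)CC(C(=O)NCCCCCNC(=O)C1=NO[C@]3(C=C(Br)C(=O)[C@H](Br)[C@@H]3O)C1)=NO2`, a stereoisomer of compound 1: the two compounds have the same atoms and bonds and differ only in configuration as drawn: 1 of 5 stereo elements differ; a stereocentre at a saturated ring carbon is drawn S in compound 1 and R in compound 4. Going by the values given here, no measured pair differs in one place only, so the data give no direct size for such a change in this assay. No step beyond the scatter is expected, in either direction, though a larger one cannot be excluded. The expected change is a 1.1-fold higher number from compound 1 to compound 4 (0.03 log units; within the scatter). The estimate for compound 4 is 3000 nM, with an expected range of 1200 nM to 8000 nM.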

Compound 4, concentration for 50% growth inhibition: 4800 nM
The estimate for compound 4 lay 1.6-fold (0.20 log units) below the measured number, within the range that was stated.
By their numbers in this assay, from the lowest: compounds 2, 1, 3 and 4 (each within the scatter of the next, the first and the last beyond it).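

The stereocentre at a saturated ring carbon, going from S to R, gives a 1.7-fold higher number from compound 1 to compound 4 (0.23 log units; within the scatter) in this assay. Going by these compounds alone, this is the first pair that differs in one place, and at this stereocentre the configuration as drawn leaves growth inhibition within the scatter. The reading rests on a clean comparison: the fact that compounds 1 and 4 differ only in the configuration as drawn

The other four stereo elements remain unread. Also open, going by these compounds, is whether this stereocentre stays as quiet with a longer chain in the linker, or with an amine on the core.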